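The source may hold more compounds than are shown below. What is called first, only, known or untested is meant among the compounds shown, and "the series" means these compounds.

In a functional assay for inhibition, with Homo sapiens as the target (a lower number here means a stronger inhibitor, a higher number a weaker inhibitor), compound 1 (`Oc1cc2c(cc1CNc1ccc(F)cc1F)OCC2`) gives 660 nM, while compound 2 (`Oc1cc2ccoc2cc1CNc1ccccc1`) gives 11000 nM. Compound 2 therefore has the higher of the two numbers, making it the weaker inhibitor, and the gap lies beyond the usual scatter. Compound 3 (`OCc1ccccc1NCc1cc2occc2cc1O`) has one structural change from compound 2: hydroxymethyl in place of hydrogen on an aromatic carbon, ortho to a large group (hydroxymethyl in place of hydrogen on an aromatic carbon). Among the measured compounds shown here, no measured pair shows this change, so the expectation is loose. The expected result is a 1.6-fold lower number from compound 2 to compound 3 (0.20 log units; within the scatter), with no change beyond the scatter. Compound 3 is estimated at 7000 nM, with an expected range of 1500 nM to 30000 nM.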

Compound 3, half-maximal inhibitory concentration in the Homo sapiens assay: 42000 nM
For compound 3 the middle estimate is 6.0-fold (0.78 log units) below the measured one; measured number above the stated range.
By their numbers in the Homo sapiens assay, from the lowest: compound 1; then compound 2; then compound 3.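

Among the compounds shown here, compound 2 and compound 3 form the first measured pair for this change, on an aromatic carbon ortho to a large group. In the Homo sapiens assay, hydroxymethyl in place of hydrogen brings a 3.8-fold higher number from compound 2 to compound 3 (0.58 log units; beyond the scatter) and so gives a weaker inhibitor. In a physicochemical assay for lipophilicity (a higher number here means a more lipophilic compound, a lower number a more polar compound), compound 2 gives 3.3 and compound 3 gives 2.2. The same change makes the compound more polar: the measured partition coefficient of compound 2, 3.3, and of compound 3, 2.2, a number 1.10 log units lower (beyond the scatter).

This single pair cannot separate the weaker inhibition from the drop in lipophilicity. From the compounds shown here alone, how a methyl, a methoxy or an amine would behave at this position remains open, as does the same change on the core of compound 1.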